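Nitropyrimidine glycinate esters: anilino in place of benzylamino

The compounds below may be only part of what the source reports. "The series", "measured", "known", "first", "only" and "open" are said of these compounds alone.

Measured compounds in a functional assay on HepG2 cells (Homo sapiens) for antiproliferative activity, read by MTT assay, with a stated time of 48 h; on this read-out higher numbers stand for weaker inhibition and lower numbers for stronger inhibition:
compound 1 `CCOC(=O)CN(Cc1ccccc1)c1nc(NCc2ccccc2)ncc1[N+](=O)[O-]` gives 21000 nM.
compound 2 `CCOC(=O)CNc1nc(Nc2ccc(Cl)cc2)ncc1[N+](=O)[O-]` gives > 100000 nM, a limit of the assay.
compound 3 `CCOC(=O)CNc1nc(NCc2ccccc2)ncc1[N+](=O)[O-]` gives > 100000 nM, a limit of the assay.

Among the measured compounds shown here, compound 1 holds the only actual number in the set; the other two entries are limits (the limit of > 100000 nM in this assay, at which 2 of the 3 values shown sit). Compound 4 `CCOC(=O)CN(Cc1ccccc1)c1nc(Nc2ccccc2)ncc1[N+](=O)[O-]` differs from compound 1 in phenyl in place of benzyl on a nitrogen on an aromatic ring. For the measured compounds named here, no measured step covers this exact change. The change an at least 4.7-fold higher number from compound 1 to compound 3 (0.67 log units; beyond the scatter) concerns the other nitrogen and is beyond the scatter, but does not inform a benzyl-to-phenyl swap. The step that the two limits leave unreadable from compound 2 to compound 3 is the nearest analogue, yet it is unreadable. No direction can therefore be read for compound 4 in this assay; the expected step of a 1.4-fold higher number from compound 1 to compound 4 (0.15 log units; within the scatter) is within scatter. Compound 4 is estimated at 30000 nM, range 8000 nM to 120000 nM.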

Compound 4, half-maximal inhibitory concentration: 44400 nM
For compound 4 the middle estimate is 1.5-fold (0.17 log units) below the measured one, and the stated range covers the measured number.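

In this assay, the change from benzylamino to anilino now has a readable comparison, with phenyl in place of benzyl on a nitrogen on an aromatic ring giving a 2.1-fold higher number from compound 1 to compound 4 (0.33 log units; beyond the scatter). The step is modest and is read with the benzyl group on the other nitrogen kept in place. The earlier comparison of this kind, between compound 2 and compound 3, cannot be read because both entries are limits: the limit of > 100000 nM in this assay, at which 2 of the 4 values shown sit.

Still open, as far as these compounds go, is how a longer chain, such as phenethyl, would read at this nitrogen. Also open, from the compounds shown here alone, is whether a carboxylic acid in place of the ethyl ester would shift the number for compound 4.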